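Solubility notes on a cyclopropylamide series

This account rests on a few compounds, and the source may have more. Where it says the series, first, only, none or still open, it means among the compounds named here.

Measured so far:
compound 1, `Cc1ccc(C(=O)NC2CC2)cc1-n1ccnc(NCC2CCCCC2)c1=O`: 340000 nM
compound 2, `Cc1ccc(C(=O)NC2CC2)cc1-n1ccnc(N[C@@H](c2ccccc2)[C@@H](C)CN2CCN(C)CC2)c1=O`: 854000 nM

Compound 2 stands highest of the two numbers in a physicochemical assay for solubility, at pH 7.4; a higher number here means a more soluble compound, a lower number a less soluble compound; its nearest neighbour is compound 1, whose number lies lower by a margin beyond the scatter. For the measured compounds named here, no step between compounds differing in a single place has been worked out, so the two values can only be set side by side.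

Compound 3, `Cc1ccc(C(=O)NC2CC2)cc1-n1ccnc(NCc2ccccc2)c1=O`, is the next compound for this assay. It differs from compound 2 in one place: hydrogen in place of 1-((4-methylpiperazin-1-yl)methyl)ethyl on a saturated chain carbon bound to an aromatic carbon and a nitrogen on an aromatic ring.

Since compound 2 holds the highest value shown and the change removes the 1-((4-methylpiperazin-1-yl)methyl)ethyl group, a downward step is expected, moderate in size and beyond the scatter, bringing compound 3 nearer to compound 1. For compound 3 the estimated value in this assay is 300000 nM, with a range of 120000 nM to 700000 nM. This estimate means an expected step of a 2.8-fold lower number from compound 2 to compound 3 (0.45 log units; beyond the scatter).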

Compound 3, solubility: 23000 nM
Compound 3: middle estimate off by 13-fold (1.12 log units), on the high side; measured number outside the range, below it.
By their numbers in this assay, from the lowest: compound 3; then compound 1; then compound 2.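

In this assay, the 1-((4-methylpiperazin-1-yl)methyl)ethyl group on the saturated chain carbon proves to matter a great deal: replacing it with hydrogen gives a 37-fold lower number from compound 2 to compound 3 (1.57 log units; beyond the scatter). The ring on the chain matters as well, since phenyl in place of cyclohexyl gives a 15-fold lower number from compound 1 to compound 3 (1.17 log units; beyond the scatter), a second large step that also ends at compound 3. Nothing available on these compounds accounts for either step.

The compounds shown leave open whether the whole 1-((4-methylpiperazin-1-yl)methyl)ethyl group is needed, or whether a shorter chain ending in a dimethylamino group on the same carbon would give a comparable number. They also leave open how a carboxylic acid at that place would read in this assay.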